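Removal of the isobutyl branch from compound 1

The compounds below may be only part of what the source reports. "The series", "measured", "known", "first", "only" and "open" are said of these compounds alone.

Compound 1 `Cc1cn([C@H]2CCCN([C@H](CC(C)C)c3ccc(C(=O)O)c(Oc4cccc(Cl)c4)c3F)C2)c(=O)[nH]c1=O` is the most lipophilic of the three measured here: in a physicochemical assay for lipophilicity, using the shake flask method, in phosphate buffer, measured as octanol-water partition, at pH 7.4 (a higher number here means a more lipophilic compound, a lower number a more polar compound), compound 1 gives 0.92. Compound 2 `CC[C@@H](c1ccc(C(=O)O)c(Oc2cccc(Cl)c2)c1)N1CCC[C@H](n2cc(C)c(=O)[nH]c2=O)C1` gives 0.22 and compound 3 `CC[C@H](c1ccc(C(=O)O)c(Oc2cccc(Cl)c2)c1)N1CCC[C@H](n2cc(C)c(=O)[nH]c2=O)C1` gives 0.22; the step of no change at the digits printed from compound 2 to compound 3 (within the scatter) is consistent with the fact that compounds 2 and 3 differ only in the configuration as drawn. Within the data shown here, compound 1 stands above both by a gap beyond the scatter, but the two differ from compound 1 in more than one place, so no single measured step bears on the change to compound 4 `Cc1cn([C@H]2CCCN(Cc3ccc(C(=O)O)c(Oc4cccc(Cl)c4)c3F)C2)c(=O)[nH]c1=O`, which is hydrogen in place of isobutyl on a saturated chain carbon bound to an amine nitrogen in a ring and an aromatic carbon. Loss of four carbons with no new donor or acceptor is expected to lower the distribution coefficient by a step larger than the measured ones, giving an expected a number 1.42 log units lower from compound 1 to compound 4 (beyond the scatter). Compound 4 is therefore estimated at -0.5, within -1.2 to 0.2.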

Compound 4, distribution coefficient: -0.59
Compound 4: the middle estimate sits 0.09 log units above what was measured; the measured number falls inside the stated range.
By their numbers in this assay, from the lowest: compound 4; then compounds 2 and 3 (each within the scatter of the next); then compound 1.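

At the saturated chain carbon bound to an amine nitrogen in a ring and an aromatic carbon, hydrogen in place of isobutyl gives, in this assay, a number 1.51 log units lower from compound 1 to compound 4 (beyond the scatter). Among these compounds, the only earlier step, a change of configuration between compound 2 and compound 3, stayed within the scatter, so this is the first single-place change to move the number beyond it. Nothing available here accounts for the size of this step.

Open, as far as these compounds go, is what a methyl group or a hydroxymethyl group at this place on the core of compound 1 would give. A single step from isobutyl to hydrogen leaves the course of the number over intermediate chains unknown.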